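A few compounds are considered here, and "the series" means these few. Any claim that something is new, unique, unknown or untested is made for them only; others in the source may bear on it.

In a functional assay on NALM-6 cells (Homo sapiens) for cytotoxicity, with a stated time of 72 h (on this read-out higher numbers stand for an effect only at larger amounts of compound and lower numbers for an effect already at smaller amounts), compound 1 (`C=C[C@@](C)(/C=C/c1ccc(Nc2ccc(F)c(F)c2)cc1)CCC=C(C)C`) gives > 43400 nM as its result, and this is a limit of the assay, not a number. Compound 2 (`C=C[C@@](C)(/C=C/c1ccc(Nc2cc(F)cc(F)c2)cc1)CCC=C(C)C`) gives > 43400 nM as its result, again only a limit, so it has no numerical position. All the evidence sits at one point (the limit of > 43400 nM in this assay, at which 2 of the 2 values shown sit). For the measured compounds named here, the one measured step, a step that the two limits leave unreadable from compound 1 to compound 2, offers no size to carry forward. Compound 3 (`C=C[C@@](C)(/C=C/c1ccc(Nc2ccc(Cl)c(F)c2)cc1)CCC=C(C)C`) has 4-chloro-3-fluorophenyl in place of 3,5-difluorophenyl on a nitrogen on an aromatic ring. Going by the values given here, with only that unreadable step to go on, no shift beyond the scatter is expected in this assay, and another limit would be the likeliest result. The expected change is a number no higher from compound 2 to compound 3 (the limit leaves the size open) and remains an estimate. The half-maximal effective concentration of compound 3 is estimated at 43000 nM with an expected range of 20000 nM to 60000 nM in this assay.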

Compound 3, half-maximal effective concentration: > 43400 nM
Compound 3 ended at the assay's limit (the forecaster's own chance of this, stated with the estimate: 75%); middle value at least 1.0-fold (0.00 log units) away from the limit.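

Compound 3 also gives only a limit in this assay, so the steps linking compound 1, compound 2 and compound 3 cannot be read: the limit of > 43400 nM in this assay, at which 3 of the 3 values shown sit. The compounds shown leave open whether these groups on the nitrogen differ at all, and at what concentration any effect would appear.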